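A few compounds are considered here, and "the series" means these few. Any claim that something is new, unique, unknown or untested is made for them only; others in the source may bear on it.

Compound 1 `CCCC[C@@H](O)C(=O)N1C[C@H]2C[C@H]2[C@H]1C(=O)NCc1cc(Cl)ccc1-n1cnnn1` and compound 3 `CCCC[C@@H](O)C(=O)N1N=CC[C@H]1C(=O)NCc1cc(Cl)ccc1-n1cnnn1` both carry the butyl group but sit on different cores, and the difference between the two cores is not broken down here. In an ADME assay on Caco-2 cells (Homo sapiens) for permeability, read by LC-MS, in the apical to basolateral direction, with a stated time of 60 min, at pH 6.5 (a higher number here means that the compound crosses the layer faster, a lower number that the compound crosses the layer more slowly), compound 1 gives 33 10^-6 cm/s, while compound 3 gives 9.8 10^-6 cm/s. Compound 2 `COC(C)(C)[C@@H](O)C(=O)N1C[C@H]2C[C@H]2[C@H]1C(=O)NCc1cc(Cl)ccc1-n1cnnn1` differs from compound 1 by 1-methoxy-1-methylethyl in place of butyl on a saturated chain carbon bound to a carbonyl carbon and an oxygen on a saturated carbon, and in this assay compound 2 gives 3.5 10^-6 cm/s, so that a 9.4-fold lower number from compound 1 to compound 2 (0.97 log units; beyond the scatter). Compound 4 `COC(C)(C)[C@@H](O)C(=O)N1N=CC[C@H]1C(=O)NCc1cc(Cl)ccc1-n1cnnn1`, not yet measured, carries the same change on the core of compound 3, namely (1-methoxy-1-methylethyl in place of butyl on a saturated chain carbon bound to a carbonyl carbon and an oxygen on a saturated carbon). Relative to compound 3 the step of a 7.5-fold lower number from compound 3 to compound 4 (0.88 log units; beyond the scatter) is expected to be of a size near the earlier one, because a 9.4-fold lower number from compound 1 to compound 2 (0.97 log units; beyond the scatter) is the only precedent in this set. For compound 4 the estimated value in this assay is 1.3 10^-6 cm/s, between 0.5 10^-6 cm/s and 3.5 10^-6 cm/s.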

Compound 4, apparent permeability: 1.7 10^-6 cm/s
Beside the measured number, compound 4's estimate is 1.3-fold (0.12 log units) below it; measured number inside the range.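

In this assay, 1-methoxy-1-methylethyl in place of butyl on the core of compound 3 gives a 5.8-fold lower number from compound 3 to compound 4 (0.76 log units; beyond the scatter). The change thus carries from one core to the other, with a step in the same direction and of a matching size: the same change on two cores in this assay, a 9.4-fold lower number (0.97 log units; beyond the scatter) from compound 1 to compound 2 and a 5.8-fold lower number (0.76 log units; beyond the scatter) from compound 3 to compound 4, 1.6-fold (0.21 log units) apart, within the scatter of two such steps. This rests on two matched pairs only, so it does not show that the step holds on any further core, and it does not show which part of the new group sets its size.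

Open, as far as these compounds go, is whether another group at this place, such as an amine, a carboxylic acid or a longer chain, would also give matching steps on both cores. Also open, from the compounds shown here alone, is whether a plain methoxy group alone would account for the step.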